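Swapping Ethoxy for Tetrazolyl on the Amide Aryl Ring

The source may hold more compounds than are shown below. What is called first, only, known or untested is meant among the compounds shown, and "the series" means these compounds.

Measured compounds:
- Compound 1 `COc1ccc(C(=O)N2C[C@H](Oc3nccc(C#N)c3C)CC[C@H]2C)c(-n2nccn2)n1`: 3 nM
- Compound 2 `Cc1c(C#N)ccnc1O[C@@H]1CC[C@@H](C)N(C(=O)c2ccccc2C(F)(F)F)C1`: 3.1 nM
- Compound 3 `CCOc1ccccc1C(=O)N1C[C@H](Oc2nccc(C#N)c2C)CC[C@H]1C`: 0.7 nM

In an assay on cells for displacement of a labelled ligand from Orexin receptor type 2 (Homo sapiens) (on this read-out higher numbers stand for weaker inhibition and lower numbers for stronger inhibition), compound 3 gives the lowest number of the three, with compound 1 and compound 2 both sitting beyond the scatter above it. Compound 4 `Cc1c(C#N)ccnc1O[C@@H]1CC[C@@H](C)N(C(=O)c2ccccc2-n2ncnn2)C1` is compound 3 with one change: 2H-tetrazol-2-yl in place of ethoxy on an aromatic carbon. Among the compounds with values here, only one measured step touches this part of the molecule, a 4.4-fold lower number from compound 2 to compound 3 (0.65 log units; beyond the scatter), which shows that the group on this aromatic carbon matters by a modest amount. Compound 1, which carries a nitrogen-rich five-membered aromatic ring instead of an ethoxy group on its amide-bearing ring, gives 3 nM, a number close to that of compound 2. Since the ethoxy group of compound 3 gave the lowest number seen here, and the two other groups tried gave higher ones, the expectation is a modest rise, a 4.3-fold higher number from compound 3 to compound 4 (0.63 log units; beyond the scatter). Compound 4 is therefore estimated at 3 nM, with a likely range from 1 nM to 10 nM.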

Compound 4, inhibition constant: 1.6 nM
For compound 4 the middle estimate is 1.9-fold (0.27 log units) above the measured one, within the range that was stated.
By their numbers in this assay, from the lowest: compound 3; then compounds 4, 1 and 2 (each within the scatter of the next).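

In this assay this aromatic carbon, ortho to a large group, now has three groups compared on the same molecule, and ethoxy alone stands apart with the lowest number. Replacing it with the larger 2H-tetrazol-2-yl ring gives a 2.3-fold higher number from compound 3 to compound 4 (0.36 log units; beyond the scatter) and so the loss is modest, which shows that a five-membered aromatic ring with 4 hetero atoms is tolerated here. Set against trifluoromethyl, the same ring gives a 1.9-fold lower number from compound 2 to compound 4 (0.29 log units; within the scatter) and so these two groups cannot be told apart on this read-out, despite having little in common as structures. Going by these compounds, whether a longer chain such as propoxy, or an amine, could match or pass ethoxy on this carbon remains open. Nothing measured here explains why the three groups fall in this order.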